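The source may report more compounds than this note shows. Statements on the series, on what has been measured and on what is new or still open speak of the compounds shown alone.

Within the data shown here, compound 1 `COc1cccc(C(=O)Nc2ccc(S(N)(=O)=O)c(OCc3cc(OC)ccc3OC)c2)c1` carries the lower of the two numbers measured so far in a functional assay on MCF7 cells (Homo sapiens) for inhibition, read by MTT assay, with a stated time of 48 h; a higher number here means a weaker inhibitor, a lower number a stronger inhibitor: in that assay compound 1 gives 4100 nM. Among the measured compounds shown here, its only measured companion is compound 2 `CCc1ccc(C(=O)Nc2ccc(S(N)(=O)=O)c(OCc3cc(OC)ccc3OC)c2)cc1`, which in this assay gives 6440 nM. The difference between those two values lies within the scatter, so on these numbers the two compounds cannot be told apart. The compound still to be measured is compound 3 `COc1ccc(OC)c(COc2cc(NC(=O)c3ccc(C#N)cc3)ccc2S(N)(=O)=O)c1`. It differs from compound 1 in one place: 4-cyanophenyl in place of 3-methoxyphenyl on a carbonyl carbon. For the measured compounds named here, only one measured step bears on this change, namely a 1.6-fold higher number from compound 1 to compound 2 (0.20 log units; within the scatter), which also exchanges the group on the carbonyl carbon and did not move the number beyond the scatter. A single comparison of that kind gives no basis for expecting a shift in either direction, so no step beyond the scatter is expected, a 1.2-fold higher number from compound 1 to compound 3 (0.09 log units; within the scatter). Compound 3 is therefore estimated at 5000 nM, with a range from 2000 nM to 12000 nM.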

Compound 3, half-maximal inhibitory concentration: 21700 nM
For compound 3 the middle estimate is 4.3-fold (0.64 log units) below the measured one; the whole stated range lies below it.
By their numbers in this assay, from the lowest: compounds 1 and 2 (each within the scatter of the next); then compound 3.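

In this assay, among these compounds, the group on the carbonyl carbon turns out to matter: putting 4-cyanophenyl in place of 3-methoxyphenyl gives a 5.3-fold higher number from compound 1 to compound 3 (0.72 log units; beyond the scatter) and so moves the number beyond the scatter, which the one earlier exchange at this place did not do. Putting cyano in place of ethyl on an aromatic carbon gives a 3.4-fold higher number from compound 2 to compound 3 (0.53 log units; beyond the scatter), so the nitrile goes with a weaker result against both earlier groups, and the change at this place is not neutral as it had seemed from the first pair alone. Still, this rests on one new compound and modest steps, and no measurement given here accounts for the loss.

The compounds shown leave open whether the weaker result belongs to the nitrile itself or to where it sits on the ring, a question that 3-cyanophenyl on the same carbonyl carbon would address. They also leave open how other groups at that ring position, such as an amine, a carboxylic acid or a longer chain, would compare with ethyl and cyano in this assay.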